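Methyl to Hydrogen: What to Expect for Compound 3

The source may hold more compounds than are shown below. What is called first, only, known or untested is meant among the compounds shown, and "the series" means these compounds.

Compound 1 `COc1ccc2c(c1)OC(c1ccccc1)CC2=O` and compound 2 `Cc1ccc(C2CC(=O)c3ccccc3O2)cc1` were both tested in an in vitro assay on BTI-TN-5B1-4 cells for inhibition of Amine oxidase [flavin-containing] B (Homo sapiens); a lower number here means a stronger inhibitor, a higher number a weaker inhibitor; there compound 1 gives 1470 nM and compound 2 gives 2070 nM. Compound 2 thus carries the highest of the two numbers, but its gap to compound 1 lies within the scatter. Compound 3 `O=C1CC(c2ccccc2)Oc2ccccc21` differs from compound 2 by hydrogen in place of methyl on an aromatic carbon. For the measured compounds named here, no measured pair shows this change, so the step in this assay is expected to be small, probably within the scatter, with a slight lean toward a higher number. Compound 3 is therefore estimated at 2500 nM, between 1000 nM and 6000 nM, an expected step of a 1.2-fold higher number from compound 2 to compound 3 (0.08 log units; within the scatter).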

Compound 3, half-maximal inhibitory concentration: 2870 nM
For compound 3 the middle estimate is 1.1-fold (0.06 log units) below the measured one; low and high end bracket the measured number.
By their numbers in this assay, from the lowest: compounds 1, 2 and 3 (each within the scatter of the next).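

In this assay, hydrogen in place of methyl on an aromatic carbon gives a 1.4-fold higher number from compound 2 to compound 3 (0.14 log units; within the scatter) and removing the methoxy group gives a 2.0-fold higher number from compound 1 to compound 3 (0.29 log units; within the scatter) as the two single-place steps. Compounds 1 and 2 differ in more than one place, so only compound 3 allows either group to be set against hydrogen, and neither step leaves the scatter. No data at hand bear on these steps.

Going by these compounds, whether an amine, a carboxylic acid or a longer chain at these places would shift the number beyond the scatter remains open.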